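Changing One Ring on a Shared Core

The source may report more compounds than this note shows. Statements on the series, on what has been measured and on what is new or still open speak of the compounds shown alone.

In a functional assay on THP-1 cells (Homo sapiens) for inhibition, read by ELISA, with stated times of 1 h and 18 h (on this read-out higher numbers stand for weaker inhibition and lower numbers for stronger inhibition), three compounds share one core and differ only in the group on a single aromatic carbon. Compound 1 `NC(=O)[C@@H]1[C@H](Nc2nc(Nc3cccc(C(=O)N4CCCC4)c3)ncc2-c2ccoc2)[C@H]2C=C[C@@H]1C2`, carrying furan-3-yl, gives 40 nM. Compound 2 `NC(=O)[C@@H]1[C@H](Nc2nc(Nc3cccc(C(=O)N4CCCC4)c3)ncc2-c2ccccc2)[C@H]2C=C[C@@H]1C2`, carrying phenyl, gives 220 nM. Compound 3 `NC(=O)[C@@H]1[C@H](Nc2nc(Nc3cccc(C(=O)N4CCCC4)c3)ncc2-c2cccc(F)c2)[C@H]2C=C[C@@H]1C2`, carrying 3-fluorophenyl, gives 870 nM, the highest number of the three and so the weakest inhibition among them.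

Compound 4 `N#Cc1ccc(-c2cnc(Nc3cccc(C(=O)N4CCCC4)c3)nc2N[C@H]2[C@@H](C(N)=O)[C@@H]3C=C[C@H]2C3)cc1` has not yet been measured. It carries 4-cyanophenyl in place of 3-fluorophenyl on an aromatic carbon. For the measured compounds named here, no measured compound carries a nitrile, so no step speaks to this swap directly. Two steps show how far this place can move the number: a 22-fold higher number from compound 1 to compound 3 (1.34 log units; beyond the scatter) is large, and a 5.5-fold higher number from compound 1 to compound 2 (0.74 log units; beyond the scatter) is modest. The nearest guide is a 4.0-fold higher number from compound 2 to compound 3 (0.60 log units; beyond the scatter), a modest rise on adding fluoro to the phenyl ring. Compound 4 loses that fluoro, so a value nearer compound 2 at 220 nM seems plausible, although the nitrile could push it either way. The expected change is a modest one towards a lower number, a 2.5-fold lower number from compound 3 to compound 4 (0.40 log units; beyond the scatter). For compound 4 the estimated value is 350 nM, with an expected range from 100 nM to 1200 nM.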

Compound 4, half-maximal inhibitory concentration: 190 nM
Beside the measured number, compound 4's estimate is 1.8-fold (0.27 log units) above it, within the range that was stated.
By their numbers in this assay, from the lowest: compound 1; then compounds 4 and 2 (each within the scatter of the next); then compound 3.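

In this assay the step to 4-cyanophenyl brings a 4.6-fold lower number from compound 3 to compound 4 (0.66 log units; beyond the scatter) and so recovers what the 3-fluorophenyl group gave up, which shows that a group added to the phenyl ring at this position does not always raise the number. Cyano in place of hydrogen gives a 1.2-fold lower number from compound 2 to compound 4 (0.06 log units; within the scatter) on the phenyl ring, so the nitrile leaves the read-out where the unsubstituted ring had it, and the two compounds cannot be told apart here. Furan-3-yl keeps its lead over the nitrile-bearing ring, with a 4.8-fold higher number from compound 1 to compound 4 (0.68 log units; beyond the scatter) separating them, but nothing in the data shown accounts for any of these differences.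

The step from 3-fluorophenyl to 4-cyanophenyl changes both the group and its place on the phenyl ring, and with neither 4-fluorophenyl nor 3-cyanophenyl among the compounds shown, the two effects cannot be separated. Also open, as far as these compounds go, is how this position would respond to a phenyl ring carrying an aminomethyl group or a carboxylic acid, and whether another small ring such as thiophene would match furan-3-yl.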